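Chloro Substitution on Purine Nucleosides in HeLa Cell Growth

The source may report more compounds than this note shows. Statements on the series, on what has been measured and on what is new or still open speak of the compounds shown alone.

Compound 1 `CNc1ncnc2c1ncn2[C@@H]1O[C@H]([C@H](O)CO)[C@@H](O)[C@H]1O` and compound 2 `CNc1nc(Cl)nc2c1ncn2[C@@H]1O[C@H]([C@H](O)CO)[C@@H](O)[C@H]1O` differ by chloro in place of hydrogen on an aromatic carbon. In a functional assay on HeLa cells (Homo sapiens), read by colorimetric assay, with a stated time of 48 h (on this read-out lower numbers stand for stronger inhibition and higher numbers for weaker inhibition), compound 1 gives only a limit, > 100000 nM. In this assay compound 2 likewise gives only a limit, > 100000 nM. Between them lies a step that the two limits leave unreadable from compound 1 to compound 2. Compound 3 `CC(=O)OC[C@@H](OC(C)=O)[C@H]1O[C@@H](n2cnc3c(Cl)ncnc32)[C@H](OC(C)=O)[C@@H]1OC(C)=O` has a core whose difference from compound 1 is not broken down here; in this assay compound 3 gives only a limit, > 100000 nM. Compound 4 `CC(=O)OC[C@@H](OC(C)=O)[C@H]1O[C@@H](n2cnc3c(Cl)nc(Cl)nc32)[C@H](OC(C)=O)[C@@H]1OC(C)=O` differs from compound 3 by chloro in place of hydrogen on an aromatic carbon, the same kind of change as before, though here the place is meta to a chloro group rather than meta to a methylamino group. Because all values sit at the limit of > 100000 nM in this assay, at which 3 of the 3 values shown sit, the step from compound 3 to compound 4 is expected to be a step that the limit leaves unreadable from compound 3 to compound 4. Compound 4 is therefore estimated at 150000 nM, spanning 30000 nM to 600000 nM.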

Compound 4, half-maximal inhibitory concentration: 24200 nM
The estimate for compound 4 lay 6.2-fold (0.79 log units) above the measured number; measured number below the stated range.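

In this assay, chloro in place of hydrogen on an aromatic carbon gives an at least 4.1-fold lower number from compound 3 to compound 4 (0.61 log units; beyond the scatter), so on the core of compound 3 the change goes with stronger inhibition, beyond the scatter. This single readable step does not show that the change carries over to other cores. The same change from compound 1 to compound 2 cannot be read, and the step on the core of compound 3 has only a lower bound, because most of the series rests on one limit: the limit of > 100000 nM in this assay, at which 3 of the 4 values shown sit.

On these data alone, it remains open whether a bromo or methoxy group in the same place would give a similar step. As far as these compounds go, it also remains open whether the step would persist with a primary amine on the shared core.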